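A few compounds are considered here, and "the series" means these few. Any claim that something is new, unique, unknown or untested is made for them only; others in the source may bear on it.

In a functional assay on MIA PaCa-2 cells (Homo sapiens) for inhibition, read by MTT assay, with a stated time of 3 days (a higher number here means a weaker inhibitor, a lower number a stronger inhibitor), the measured compounds give:

compound 1 `CC(C)c1noc(N2CCN(C(=O)[C@@H]3CCCN(S(=O)(=O)c4ccc(S(=O)(=O)C5CCC5)cc4)C3)CC2)n1`: 20 nM
compound 2 `CC(C)c1noc(N2CCN(C(=O)[C@@H]3CCCN(S(=O)(=O)c4ccc(S(=O)(=O)NC(C)(C)C)cc4)C3)CC2)n1`: 100 nM
compound 3 `CC(C)NS(=O)(=O)c1ccc(S(=O)(=O)N2CCC[C@@H](C(=O)N3CCN(c4nc(C(C)C)no4)CC3)C2)cc1`: 200 nM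

Compound 3 holds the highest number of the three: a 2.0-fold higher number from compound 2 to compound 3 (0.30 log units; within the scatter) lies within the scatter, whereas a 10-fold higher number from compound 1 to compound 3 (1.00 log units; beyond the scatter) lies beyond it. Compound 4 `CCNS(=O)(=O)c1ccc(S(=O)(=O)N2CCC[C@@H](C(=O)N3CCN(c4nc(C(C)C)no4)CC3)C2)cc1` differs from compound 3 by hydrogen in place of methyl on a saturated chain carbon bound to a saturated chain carbon and a sulfonamide nitrogen. The step that bears most directly is the one that likewise put hydrogen in place of methyl on a saturated chain carbon bound to a sulfonamide nitrogen, a 2.0-fold higher number from compound 2 to compound 3 (0.30 log units; within the scatter), a change within the scatter. The steps of a 5.0-fold higher number from compound 1 to compound 2 (0.70 log units; beyond the scatter) and a 10-fold higher number from compound 1 to compound 3 (1.00 log units; beyond the scatter) concern a different replacement and give less guidance. Compound 4 is therefore expected to show a 1.3-fold higher number from compound 3 to compound 4 (0.10 log units; within the scatter) in this assay, no more than the scatter. The estimate for compound 4 is 250 nM, with a range from 100 nM to 600 nM.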

Compound 4, half-maximal inhibitory concentration: 200 nM
Estimate against measurement, compound 4: 1.3-fold (0.10 log units) above, and the stated range covers the measured number.
By their numbers in this assay, from the lowest: compound 1; then compounds 2, 3 and 4 (each within the scatter of the next).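

In this assay, the step of no change at the digits printed from compound 3 to compound 4 (within the scatter) shows that cutting isopropylamino back to ethylamino on this sulfonamide nitrogen leaves the reading flat. Ethyl in place of tert-butyl on that nitrogen gives a 2.0-fold higher number from compound 2 to compound 4 (0.30 log units; within the scatter) and so also stays level, whereas ethylamino in place of cyclobutyl on the sulfonyl sulfur gives a 10-fold higher number from compound 1 to compound 4 (1.00 log units; beyond the scatter) and repeats the gap seen for the other amino groups. No measured evidence here explains these numbers. Going by these compounds, whether a methylamino group, a bare amino group or a longer chain such as n-butylamino would stay at this level remains open.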